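The compounds below may be only part of what the source reports. "The series", "measured", "known", "first", "only" and "open" are said of these compounds alone.

Three compounds share one core and differ only in a single group on an aromatic carbon. Compound 1 `Cc1ccc(S(=O)(=O)N2C/C(=C\c3ccccc3F)C(=O)/C(=C/c3ccccc3F)C2)cc1` carries a methyl there, and in a functional assay on HepG2 cells (Homo sapiens) for cytotoxicity, read by MTT assay, with a stated time of 24 h (a lower number here means a stronger inhibitor, a higher number a weaker inhibitor), compound 1 gives 14200 nM. Compound 2 `O=C1/C(=C/c2ccccc2F)CN(S(=O)(=O)c2ccc(C(F)(F)F)cc2)C/C1=C\c1ccccc1F` carries a trifluoromethyl instead, and in this assay compound 2 gives 4900 nM, the lowest of the three numbers. Compound 3 `N#Cc1ccc(S(=O)(=O)N2C/C(=C\c3ccccc3F)C(=O)/C(=C/c3ccccc3F)C2)cc1` carries a cyano, and in this assay compound 3 gives 16500 nM. The steps are a 2.9-fold lower number from compound 1 to compound 2 (0.46 log units; beyond the scatter), a 3.4-fold higher number from compound 2 to compound 3 (0.53 log units; beyond the scatter) and a 1.2-fold higher number from compound 1 to compound 3 (0.07 log units; within the scatter). Compound 4 `CC(=O)Nc1ccc(S(=O)(=O)N2C/C(=C\c3ccccc3F)C(=O)/C(=C/c3ccccc3F)C2)cc1` is not yet measured; it differs from compound 2 in that (acetamido in place of trifluoromethyl on an aromatic carbon). Among the compounds with values here, the steps that bear on this change are the two in which the trifluoromethyl is swapped against another group: both times the other group gave a modestly higher number, as the step from compound 2 to compound 3 shows with a 3.4-fold higher number from compound 2 to compound 3 (0.53 log units; beyond the scatter). A modest rise in this assay is therefore expected for compound 4, roughly a 2.4-fold higher number from compound 2 to compound 4 (0.39 log units; beyond the scatter). Compound 4 is estimated at 12000 nM, with a range from 5000 nM to 30000 nM.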

Compound 4, half-maximal inhibitory concentration: 5200 nM
Estimate against measurement, compound 4: 2.3-fold (0.36 log units) above, and the stated range covers the measured number.
By their numbers in this assay, from the lowest: compounds 2 and 4 (each within the scatter of the next); then compounds 1 and 3 (each within the scatter of the next).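

In this assay, acetamido and trifluoromethyl cannot be told apart at this position, with a 1.1-fold higher number from compound 2 to compound 4 (0.03 log units; within the scatter), even though acetamido brings a hydrogen-bond donor and a hydrogen-bond acceptor that trifluoromethyl lacks. Acetamido also stands clear of the other two groups, with a 2.7-fold lower number from compound 1 to compound 4 (0.44 log units; beyond the scatter) and a 3.2-fold lower number from compound 3 to compound 4 (0.50 log units; beyond the scatter), so trifluoromethyl is no longer the only group here that gives a lower number than methyl and cyano. Nothing available explains why two such different groups give matching numbers here.

On these data alone, whether an amine or a carboxylic acid at this place would group with compound 2 and compound 4, or with compound 1 and compound 3, remains open. So does the outcome of replacing acetamido with an amide bearing a longer chain.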